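The compounds below may be only part of what the source reports. "The series", "measured", "known", "first", "only" and "open" are said of these compounds alone.

Of the compounds shown here, two sharing one core have been measured in a functional assay on HEK293 cells for agonist activity at Bile acid receptor (Homo sapiens); a higher number here means that more compound is needed for the effect, a lower number that less compound is needed. Compound 1 `CN(Cc1ccc(C(=O)O)cc1)c1ccc(OCc2c(-c3c(Cl)cccc3Cl)noc2C2CC2)nc1C(F)(F)F` gives 30 nM in this assay. Compound 2 `O=C(O)c1ccc(OCc2ccc(OCc3c(-c4c(Cl)cccc4Cl)noc3C3CC3)nc2C(F)(F)F)cc1` gives 95 nM in this assay, and it stands at the higher of the two numbers: the change from compound 1 to compound 2 brought a 3.2-fold higher number from compound 1 to compound 2 (0.50 log units; beyond the scatter), so compound 2 needs more of the compound for the same effect than compound 1 does.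

The next compound, compound 3 `CC(Oc1cccc(C(=O)O)c1)c1ccc(OCc2c(-c3c(Cl)cccc3Cl)noc2C2CC2)nc1C(F)(F)F`, is reached from compound 2 by a single change, (1-(3-carboxyphenoxy)ethyl in place of (4-carboxyphenoxy)methyl on an aromatic carbon). Within the data shown here, no measured step covers this kind of change, since the only step recorded concerns the linker that joins the carboxyphenyl part to the core, not the placing of the carboxylic acid on that ring or the added methyl on the linking carbon. Among the measured compounds shown here, the one recorded step was modest, and a change of comparable size is the most that can reasonably be drawn from it. Compound 3 is therefore expected to show a 1.6-fold higher number from compound 2 to compound 3 (0.20 log units; within the scatter) in this assay, with a somewhat higher number considered slightly more likely than a lower one. The estimate for compound 3 in this assay is 150 nM, within a range from 40 nM to 600 nM.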

Compound 3, half-maximal effective concentration: 107 nM
For compound 3 the middle estimate is 1.4-fold (0.15 log units) above the measured one; measured number inside the range.
By their numbers in this assay, from the lowest: compound 1; then compounds 2 and 3 (each within the scatter of the next).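

In this assay, the swap at this position, ortho to a trifluoromethyl group, gives a 1.1-fold higher number from compound 2 to compound 3 (0.05 log units; within the scatter), so the 1-(3-carboxyphenoxy)ethyl and (4-carboxyphenoxy)methyl groups cannot be told apart here, even though the carboxylic acid sits differently on the ring and the linking carbon carries an added methyl. The (4-carboxybenzyl)(methyl)amino group keeps its distance from this new group as well, with a 3.6-fold higher number from compound 1 to compound 3 (0.55 log units; beyond the scatter), so compounds 2 and 3, both of which join the carboxyphenyl part through oxygen, lie on the same side of compound 1. No available evidence bears on the reason for these results.

Because compound 3 differs from compound 2 in two features at once, the compounds shown leave open whether the placing of the carboxylic acid and the added methyl each matter little or instead offset each other, which a (3-carboxyphenoxy)methyl or a 1-(4-carboxyphenoxy)ethyl group would separate. They also leave open how the (methyl)amino linker of compound 1 would fare with the carboxylic acid placed as in compound 3, or with a tetrazole in place of that acid.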